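A Fluoro Step on the Benzyl Group of Compound 3

The compounds below may be only part of what the source reports. "The series", "measured", "known", "first", "only" and "open" are said of these compounds alone.

In a functional assay on RS4-11 cells (Homo sapiens) for inhibition, read by CCK-8 assay, with a stated time of 48 h (on this read-out higher numbers stand for weaker inhibition and lower numbers for stronger inhibition), compound 3 `COc1ccc(S(=O)(=O)Oc2ccccc2/C=C(\C#N)C(=O)Nc2nnc(Cc3ccccc3)s2)cc1` gives 1060 nM and stands within the scatter of the other two measured compounds. Compound 1 `COc1ccc(Cc2nnc(NC(=O)/C(C#N)=C/c3ccccc3OS(=O)(=O)c3ccc(OC)cc3)s2)cc1` gives 840 nM in the same test, and compound 2 `COc1ccc(S(=O)(=O)Oc2ccccc2/C=C(\C#N)C(=O)Nc2nnc(Cc3cccc4ccccc34)s2)cc1` gives 1360 nM there too.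

Compound 4 `COc1ccc(S(=O)(=O)Oc2ccccc2/C=C(\C#N)C(=O)Nc2nnc(Cc3ccc(F)cc3)s2)cc1` departs from compound 3 in one place only: fluoro in place of hydrogen on an aromatic carbon. This is fluoro in place of hydrogen on an aromatic carbon, para to a large group, so that benzyl becomes 4-fluorobenzyl.

The step closest to this one puts hydrogen in place of methoxy on that same aromatic carbon, and it comes to a 1.3-fold higher number from compound 1 to compound 3 (0.10 log units; within the scatter). Exchanges of the whole aryl group bear on it less directly. Naphthalen-1-yl in place of 4-methoxyphenyl gives a 1.6-fold higher number from compound 1 to compound 2 (0.21 log units; within the scatter), and phenyl in place of naphthalen-1-yl gives a 1.3-fold lower number from compound 2 to compound 3 (0.11 log units; within the scatter).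

Judging from the step of a 1.3-fold higher number from compound 1 to compound 3 (0.10 log units; within the scatter), no step beyond the scatter is expected in this assay for the exchange of hydrogen for fluoro. The expected change is a 1.1-fold lower number from compound 3 to compound 4 (0.05 log units; within the scatter) and no clear direction can be argued. The estimate for compound 4 is 950 nM, with an expected range of 500 nM to 1800 nM.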

Compound 4, half-maximal inhibitory concentration: 1210 nM
Estimate against measurement, compound 4: 1.3-fold (0.11 log units) below; measured number inside the range.
By their numbers in this assay, from the lowest: compounds 1, 3, 4 and 2 (each within the scatter of the next).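

In this assay, fluoro in place of hydrogen on this aromatic carbon gives a 1.1-fold higher number from compound 3 to compound 4 (0.06 log units; within the scatter) and so adds a third group at this place, after hydrogen and methoxy, without a step beyond the scatter. Fluoro in place of methoxy gives a 1.4-fold higher number from compound 1 to compound 4 (0.16 log units; within the scatter) as its step, and 4-fluorophenyl in place of naphthalen-1-yl gives a 1.1-fold lower number from compound 2 to compound 4 (0.05 log units; within the scatter) as its step, so that every exchange of the aryl end among these four compounds now stays within the scatter, with none going against this. Nothing at hand offers a reason for so even a set of numbers, and the result cannot be tied to any measured property of fluoro.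

Whether this evenness would hold for an amine, a carboxylic acid or trifluoromethyl on the same aromatic carbon remains open, since the compounds shown carry only hydrogen, fluoro and methoxy there. Also open, going by these compounds, is what a longer chain in place of the benzyl link would do, and whether a change to the shared core would produce a step beyond the scatter in this cell test.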